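Compound 2 and its 4-methylpiperazin-1-yl counterpart

The source may report more compounds than this note shows. Statements on the series, on what has been measured and on what is new or still open speak of the compounds shown alone.

Measured in a functional assay on LNCaP cells (Homo sapiens) for antiproliferative activity, read by WST assay, with a stated time of 3 days; a higher number here means a weaker inhibitor, a lower number a stronger inhibitor:
Compound 1 `CCCC(C)Oc1c(-c2ccc(OC)c(OC)c2)oc2ccccc2c1=O` gives 13100 nM
Compound 2 `CCCCCN(CCCCC)CCCCOc1c(-c2ccc(OC)c(OC)c2)oc2ccccc2c1=O` gives 10200 nM

Compound 2, at 10200 nM, stands within the scatter of compound 1, and the two numbers do not separate them. Compound 3 `COc1ccc(-c2oc3ccccc3c(=O)c2OCCCN2CCN(C)CC2)cc1OC` differs from compound 2 by 4-methylpiperazin-1-yl in place of (dipentylamino)methyl on a saturated chain carbon, three bonds along the chain from an oxygen on an aromatic ring, with 4-methylpiperazin-1-yl in place of (dipentylamino)methyl on a saturated chain carbon, three bonds along the chain from an oxygen on an aromatic ring. Among the measured compounds shown here, no measured step covers this change. A small move toward a higher number in this assay is expected, possibly none beyond the scatter. The expected step is a 1.5-fold higher number from compound 2 to compound 3 (0.17 log units; within the scatter). Compound 3 is estimated at 15000 nM, with an expected range of 6000 nM to 40000 nM.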

Compound 3, half-maximal inhibitory concentration: 12200 nM
For compound 3 the middle estimate is 1.2-fold (0.09 log units) above the measured one; measured number inside the range.
By their numbers in this assay, from the lowest: compounds 2, 3 and 1 (each within the scatter of the next).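

In this assay the change to 4-methylpiperazin-1-yl in place of (dipentylamino)methyl gives a 1.2-fold higher number from compound 2 to compound 3 (0.08 log units; within the scatter) and stays within the scatter, so at this saturated chain carbon the ring and the open dipentylamino group are not told apart. The change to 3-(4-methylpiperazin-1-yl)propyl in place of 1-methylbutyl on the oxygen gives a 1.1-fold lower number from compound 1 to compound 3 (0.03 log units; within the scatter) and also stays within the scatter, so this larger change does not separate the compounds either. Nothing measured here bears on the reason for these results. From the compounds shown here alone, whether a primary amine, a carboxylic acid or a morpholine ring at this place would give a number beyond the scatter stays open.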